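Aryl substituent series: trifluoromethyl in place of methoxy

This account rests on a few compounds, and the source may have more. Where it says the series, first, only, none or still open, it means among the compounds named here.

Compound 1 `c1ccc(-c2nc3cccnc3o2)cc1` bears no substituent on the six-membered aromatic ring of carbon only. In a functional assay on the whole organism for inhibition, with Rattus norvegicus as the target, at a dose of 30 mg/kg (on this read-out higher numbers stand for more inhibition at the one dose given (going by the name of the read-out) and lower numbers for less inhibition), compound 1 gives 55%. Compound 2 `COc1cccc(-c2nc3cccnc3o2)c1` gives 0%, the lowest of the three numbers; compound 3 `Clc1ccc(-c2nc3cccnc3o2)cc1` gives 14%. Both measured steps lower the read-out: a number 55 percentage points lower from compound 1 to compound 2 (beyond the scatter) and a number 41 percentage points lower from compound 1 to compound 3 (beyond the scatter). Compound 4 `FC(F)(F)c1cccc(-c2nc3cccnc3o2)c1` differs from compound 2 by trifluoromethyl in place of methoxy on an aromatic carbon. Going by the values given here, no measured step swaps one substituent for another, so the only bearing is that each substituted compound measured so far sits well below compound 1. For compound 4 the expected step is a number 10 percentage points higher from compound 2 to compound 4 (within the scatter), likely within the scatter. The estimate for compound 4 is 10%, with a range from 0% to 35%.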

Compound 4, a percentage reported as inhibition, in the whole organism at one dose (the size of the read-out at that dose, not a potency): 7%
Estimate against measurement, compound 4: 3 percentage points above; low and high end bracket the measured number.
By their numbers in this assay, from the lowest: compounds 2, 4 and 3 (each within the scatter of the next, the first and the last beyond it); then compound 1.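

In this assay, going by these compounds alone, the first direct swap of one substituent for another at this position (a number 7 percentage points higher from compound 2 to compound 4 (within the scatter)) does not separate methoxy from trifluoromethyl, both meta to a group of 9 heavy atoms. A second group at this place also sits far from the unsubstituted compound (a number 48 percentage points lower from compound 1 to compound 4 (beyond the scatter)), so the large loss is not confined to methoxy. No evidence on the origin of either step is available. Going by these compounds, whether an amine or a carboxylic acid at this place would keep the read-out of compound 1 stays open.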